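Trifluoromethyl for Methyl on Two Different Cores

The source may report more compounds than this note shows. Statements on the series, on what has been measured and on what is new or still open speak of the compounds shown alone.

Compound 1 `Cc1[nH]c(C(F)(F)F)cc1C(=O)O` and compound 2 `Cc1cc(C(=O)O)c(C)[nH]1` share a five-membered core, while compound 3 `Cc1cccc(N2CCC(C(=O)O)C2)c1` and the unmeasured compound 4 `O=C(O)C1CCN(c2cccc(C(F)(F)F)c2)C1` are built on a six-membered one; the difference between the two cores is not broken down here. In an assay on cells for inhibition of Palmitoleoyl-protein carboxylesterase NOTUM variant C330S (Homo sapiens), read by fluorescence, with a stated time of 40 min (on this read-out lower numbers stand for stronger inhibition and higher numbers for weaker inhibition), compound 1 gives 6700 nM. For compound 2 the assay reports only a limit, > 100000 nM (the limit of > 100000 nM in this assay, at which 1 of the 3 values shown sits). Compound 3 gives 49000 nM. The change from compound 2 to compound 1 is trifluoromethyl in place of methyl on an aromatic carbon and brought an at least 14-fold lower number from compound 2 to compound 1 (1.17 log units; beyond the scatter). The change from compound 3 to compound 4 is trifluoromethyl in place of methyl on an aromatic carbon. It is the same kind of change, yet its place differs: in compound 2 the group sits next to the ring nitrogen of a five-membered aromatic ring with 1 nitrogen, whereas in compound 3 it sits on a six-membered aromatic ring of carbon only, meta to a group of 8 heavy atoms. Compound 4 is expected to make a step of a 4.9-fold lower number from compound 3 to compound 4 (0.69 log units; beyond the scatter), an expectation that rests on an at least 14-fold lower number from compound 2 to compound 1 (1.17 log units; beyond the scatter) but is tempered by the different surroundings. Compound 4 is estimated at 10000 nM, with a likely range from 3000 nM to 40000 nM.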

Compound 4, half-maximal inhibitory concentration: 11000 nM
Compound 4: the middle estimate sits 1.1-fold (0.04 log units) below what was measured, and the stated range covers the measured number.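

In this assay, trifluoromethyl in place of methyl on an aromatic carbon lowers the number on both cores, with a 4.5-fold lower number from compound 3 to compound 4 (0.65 log units; beyond the scatter) on the core of compound 3, so the direction carries across these two cores while the size does not: the same change on two cores in this assay, an at least 14-fold lower number (1.17 log units; beyond the scatter) from compound 2 to compound 1 and a 4.5-fold lower number (0.65 log units; beyond the scatter) from compound 3 to compound 4, at least 3.3-fold (0.52 log units) apart, beyond the scatter of two such steps The step on the core of compound 1 starts from compound 2, which stands at a limit and not at a number: the limit of > 100000 nM in this assay, at which 1 of the 4 values shown sits. With a single pair on each core, this shows no rule for further cores, and it does not tell which difference between the two cores goes with the gap between the steps.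

The compounds shown leave open how a chlorine or a nitrile on the same aromatic carbon would compare with methyl and trifluoromethyl on either core. They also leave open whether the step would hold if an amide took the place of the carboxylic acid.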